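Adding a Chloro Group to Compound 2

The source may report more compounds than this note shows. Statements on the series, on what has been measured and on what is new or still open speak of the compounds shown alone.

Among the measured compounds shown here, in a functional assay on MCF7 cells (Homo sapiens) for antiproliferative activity, read by MTT assay, with a stated time of 72 h (on this read-out higher numbers stand for weaker inhibition and lower numbers for stronger inhibition), compound 2 `CCN(c1ccccc1)S(=O)(=O)C1CC2OC1C(c1ccc(NC(=O)CCCCCCC(=O)O)cc1)=C2c1ccc(O)cc1` gives 19100 nM and compound 1 `CN(c1ccc(Cl)cc1)S(=O)(=O)C1CC2OC1C(c1ccc(NC(=O)CCCCCCC(=O)O)cc1)=C2c1ccc(O)cc1` gives 13700 nM as the only other number available, so compound 2 stands level with compound 1 within the usual scatter. Compound 3 `CCN(c1ccc(Cl)cc1)S(=O)(=O)C1CC2OC1C(c1ccc(NC(=O)CCCCCCC(=O)O)cc1)=C2c1ccc(O)cc1` differs from compound 2 by chloro in place of hydrogen on an aromatic carbon in a single place: chloro in place of hydrogen on an aromatic carbon, para to a large group, which turns phenyl into 4-chlorophenyl. For the measured compounds named here, only one measured step bears on this, and it mixes the chloro with a second change, ethyl(phenyl)amino in place of (4-chlorophenyl)(methyl)amino on a sulfonyl sulfur. On the strength of a 1.4-fold higher number from compound 1 to compound 2 (0.14 log units; within the scatter) no step beyond the scatter is expected in this assay for this change. The estimated step is a 1.3-fold lower number from compound 2 to compound 3 (0.10 log units; within the scatter). Compound 3 is expected at 15000 nM with an estimated range from 8000 nM to 28000 nM.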

Compound 3, half-maximal inhibitory concentration: 22100 nM
For compound 3 the middle estimate is 1.5-fold (0.17 log units) below the measured one; measured number inside the range.
By their numbers in this assay, from the lowest: compounds 1, 2 and 3 (each within the scatter of the next).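

In this assay the chloro can now be read alone: with the ethyl group held fixed, the change from phenyl to 4-chlorophenyl gives a step within the scatter (a 1.2-fold higher number from compound 2 to compound 3 (0.06 log units; within the scatter)), which the earlier mixed step could not show. Among the compounds shown here, the methyl in place of hydrogen on the saturated chain carbon bound to the sulfonamide nitrogen can also be read alone for the first time, and it too stays within the scatter (a 1.6-fold higher number from compound 1 to compound 3 (0.21 log units; within the scatter)). Nothing measured here bears on the reason for either result.

From the compounds shown here alone, whether a different group in the same place, such as methoxy, an amine or a carboxylic acid, would give a step beyond the scatter remains open. So does the outcome of a longer chain on the sulfonamide nitrogen, such as propyl or butyl.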